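The compounds below may be only part of what the source reports. "The series", "measured", "known", "first", "only" and "open" are said of these compounds alone.

Measured so far in an assay on isolated protein for agonist activity at Free fatty acid receptor 1 (Homo sapiens); on this read-out higher numbers stand for an effect only at larger amounts of compound and lower numbers for an effect already at smaller amounts:
Compound 1, `CC#CC(CC(=O)O)c1ccc(OCc2ccc3nc(-c4ccc(C(F)(F)F)cc4)cn3c2)cc1`, gives 558 nM.
Compound 2, `CC#CC(CC(=O)O)c1ccc(OCc2ccc3nc(-c4ccc(C(C)C)cc4)cn3c2)cc1`, gives 528 nM.
Compound 3, `CC#CC(CC(=O)O)c1ccc(OCc2ccc3nc(-c4ccccc4F)cn3c2)cc1`, gives 583 nM.

Compound 3 sits within the scatter of both other compounds: the step of a 1.0-fold higher number from compound 1 to compound 3 (0.02 log units; within the scatter) and the step of a 1.1-fold higher number from compound 2 to compound 3 (0.04 log units; within the scatter) are both small. Compound 4, `CC#CC(CC(=O)O)c1ccc(OCc2ccc3nc(-c4ccc(C)cc4)cn3c2)cc1`, differs from compound 3 in the group that sits at one place of the shared core: 4-methylphenyl in place of 2-fluorophenyl on an aromatic carbon. Three earlier steps changed the group at this same place, a 1.1-fold lower number from compound 1 to compound 2 (0.02 log units; within the scatter), a 1.0-fold higher number from compound 1 to compound 3 (0.02 log units; within the scatter) and a 1.1-fold higher number from compound 2 to compound 3 (0.04 log units; within the scatter), and none of them moved the number beyond the scatter. The same is therefore expected here: a step of a 1.1-fold lower number from compound 3 to compound 4 (0.03 log units; within the scatter) in this assay, not beyond the scatter. Compound 4 is estimated at 550 nM, with a range from 280 nM to 1100 nM.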

Compound 4, half-maximal effective concentration: 507 nM
Beside the measured number, compound 4's estimate is 1.1-fold (0.04 log units) above it; the range from low to high includes it.
By their numbers in this assay, from the lowest: compounds 4, 2, 1 and 3 (each within the scatter of the next).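

Swapping 2-fluorophenyl for 4-methylphenyl gives a 1.1-fold lower number from compound 3 to compound 4 (0.06 log units; within the scatter) in this assay, so this change leaves the number within the scatter. Methyl also reads alike with the other two groups on that phenyl ring: a 1.0-fold lower number from compound 2 to compound 4 (0.02 log units; within the scatter) replaces isopropyl, and a 1.1-fold lower number from compound 1 to compound 4 (0.04 log units; within the scatter) replaces trifluoromethyl. Nothing available explains why these changes leave the number level. The compounds shown leave open whether an amine or a carboxylic acid on that phenyl ring would move the number beyond the scatter.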